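Shortening the alkylsulfanyl chain on the shared core

The source may hold more compounds than are shown below. What is called first, only, known or untested is meant among the compounds shown, and "the series" means these compounds.

Compound 1 `Nc1nc(OCC(F)(F)F)c2ncn(/C=C3/CC3(CO)CO)c2n1`: in an ADME assay on Akata cells (Homo sapiens) for cytotoxicity, with a stated time of 7 days (on this read-out higher numbers stand for lower toxicity in this test and lower numbers for higher toxicity in this test), compound 1 reaches only the assay limit, > 20000 nM.
Compound 2 `CCCCCCSc1nc(N)nc2c1ncn2/C=C1/CC1(CO)CO`: in this assay compound 2 likewise reaches only the assay limit, > 20000 nM.

Compound 2 therefore stands at a limit with no number behind it. Among the compounds with values here, the single measured step, a step that the two limits leave unreadable from compound 1 to compound 2, cannot be read because of the limit of > 20000 nM in this assay, at which 2 of the 2 values shown sit. Compound 3 `CCCCSc1nc(N)nc2c1ncn2/C=C1/CC1(CO)CO` differs from compound 2 by hydrogen in place of ethyl on a saturated chain carbon, four bonds along the chain from a sulfur. Within the data shown here, no measured step touches this chain, so no direction can be drawn from the data; the expectation is that compound 3 also stays at the limit, with a step that the limit leaves unreadable from compound 2 to compound 3 expected. Compound 3 is estimated at 30000 nM in this assay, within 15000 nM to 80000 nM.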

Compound 3, half-maximal cytotoxic concentration: > 20000 nM
Compound 3: only a limit was reported; the forecaster's own chance of this, stated with the estimate: 85%; the middle value is on the limit's open side.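

Within the data shown here, no step among compound 1, compound 2 and compound 3 can be read, because all three values stand at a limit of the assay: the limit of > 20000 nM in this assay, at which 3 of the 3 values shown sit.

The compounds shown leave open whether any alkylsulfanyl chain on the shared core gives a measurable value in this assay.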